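The source may hold more compounds than are shown below. What is called first, only, known or untested is meant among the compounds shown, and "the series" means these compounds.

Series notes. Compound 1 `Cn1c(Cc2nn(C)c(=O)c3ccccc23)nnc1SCCCCCCCC(=O)Nc1ccc(Cl)cc1Cl` gives 3900 nM in an assay on 32D cells for inhibition of interleukin-15 (Mus musculus), read by resazurin assay, with stated times of 30 min and 2.5 days, in the presence of a further agent that is not named here (a lower number here means a stronger inhibitor, a higher number a weaker inhibitor), the lowest of the two numbers recorded. Compound 2 `Cn1nc(Cc2nnc(SCC(=O)Nc3ccc(Cl)cc3Cl)n2CCC=O)c2ccccc2c1=O` gives 6400 nM, which sits within the scatter of compound 1. Compound 3 `Cn1nc(Cc2nnc(SCC(=O)Nc3ccc(Cl)cc3Cl)n2CCC(=O)O)c2ccccc2c1=O` gives only a limit, > 30000 nM. Among the compounds with values here, the single measured step, an at least 4.6-fold higher number from compound 2 to compound 3 (0.67 log units; beyond the scatter), is open-ended because of the limit of > 30000 nM in this assay, at which 1 of the 3 values shown sits. The unmeasured compound 4 `CN(C)CCCn1c(Cc2nn(C)c(=O)c3ccccc23)nnc1SCCCCCCCC(=O)Nc1ccc(Cl)cc1Cl` differs from compound 1 by 2-(dimethylamino)ethyl in place of hydrogen on a saturated chain carbon bound to an aromatic nitrogen. The step from compound 2 to compound 3 also altered the chain on the aromatic nitrogen, but it brought in a hydroxy, whereas here a dimethylamino enters, so that step is only a loose guide. No shift beyond the scatter is expected in this assay, the estimated step being a 1.1-fold lower number from compound 1 to compound 4 (0.05 log units; within the scatter). Compound 4 is expected at 3500 nM, range 1200 nM to 10000 nM.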

Compound 4, half-maximal inhibitory concentration: 5500 nM
Compound 4: middle estimate off by 1.6-fold (0.20 log units), on the low side, within the range that was stated.
By their numbers in this assay, from the lowest: compounds 1, 4 and 2 (each within the scatter of the next). At a limit, above all of these: compound 3.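

On the saturated chain carbon bound to an aromatic nitrogen, 2-(dimethylamino)ethyl in place of hydrogen gives a 1.4-fold higher number from compound 1 to compound 4 (0.15 log units; within the scatter) in this assay. The methyl of compound 1 can therefore be extended to 3-(dimethylamino)propyl with no shift beyond the scatter, the first view of an amine at this position. Nothing measured here gives a reason for this result.

On these data alone, whether a primary amine or a morpholine at the end of this chain would behave the same remains open. So does the effect of a longer chain carrying the dimethylamino group.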